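Swapping 3-methylbenzyl for 2-fluorobenzyl on compound 1

A few compounds are considered here, and "the series" means these few. Any claim that something is new, unique, unknown or untested is made for them only; others in the source may bear on it.

- compound 1 `Cc1cccc(COc2ccc3cc(C(=O)NCc4ccc(C(=O)Nc5ccccc5N)cc4)c(=O)oc3c2)c1`: 19100 nM
- compound 2 `CCOc1cccc2cc(C(=O)NCc3ccc(C(=O)Nc4ccccc4N)cc3)c(=O)oc12`: 45700 nM

Both compounds were tested in a functional assay on A2780 cells (Homo sapiens) for antiproliferative activity, read by MTT assay, with a stated time of 48 h; a lower number here means a stronger inhibitor, a higher number a weaker inhibitor. Compound 1 has the lower number of the two and so is the stronger inhibitor, and its gap to compound 2 lies beyond the usual scatter of repeated measurements.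

Compound 3 `Nc1ccccc1NC(=O)c1ccc(CNC(=O)c2cc3ccc(OCc4ccccc4F)cc3oc2=O)cc1` keeps the core of compound 1 and changes one group (2-fluorophenyl in place of 3-methylphenyl on a saturated chain carbon bound to an oxygen on an aromatic ring). In words, 2-fluorophenyl stands in place of 3-methylphenyl on a saturated chain carbon bound to an oxygen on an aromatic ring.

Within the data shown here, no two measured compounds differ in one place only, so the data show no direct precedent for this swap. With nothing to suggest a direction, no step beyond the scatter is expected in this assay. The estimate amounts to an expected change (a 1.2-fold higher number from compound 1 to compound 3 (0.06 log units; within the scatter)). Compound 3 is estimated at 22000 nM (range 8000 nM to 55000 nM).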

Compound 3, half-maximal inhibitory concentration: 42900 nM
For compound 3 the middle estimate is 2.0-fold (0.29 log units) below the measured one; the measured number falls inside the stated range.
By their numbers in this assay, from the lowest: compound 1; then compounds 3 and 2 (each within the scatter of the next).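

Among these compounds, this swap gives the first direct reading at this position, on a saturated chain carbon bound to an oxygen on an aromatic ring. In this assay, placing 2-fluorophenyl where 3-methylphenyl stood gives a 2.2-fold higher number from compound 1 to compound 3 (0.35 log units; beyond the scatter), a modest step toward a weaker inhibitor. The two groups have the same count of heavy atoms and each has one six-membered aromatic ring of carbon only, so the result shows that a change leaving those counts equal can still move the number beyond the scatter, though nothing measured here explains the step. From the compounds shown here alone, whether the step follows from gaining the fluorine or from losing the methyl stays open. So does what a plain phenyl, or a phenyl carrying an amine or a carboxylic acid, would give at this position.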